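This account rests on a few compounds, and the source may have more. Where it says the series, first, only, none or still open, it means among the compounds named here.

Measured in a functional assay on HCT-116 cells (Homo sapiens) for antiproliferative activity, read by MTT assay, with a stated time of 48 h; a lower number here means a stronger inhibitor, a higher number a weaker inhibitor:
Compound 1 `CCCCCC(CCO)n1cnc2c(N)nc(Cl)nc21`: > 50000 nM, a limit
Compound 2 `CCCCCCC(CCO)n1cnc2c(N)nc(Cl)nc21`: > 50000 nM, a limit
Compound 3 `CCCCCCCCCC(CCO)n1cnc2c(Cl)nc(Cl)nc21`: 32600 nM

For the measured compounds named here, compound 3 holds the only number, 32600 nM. Compound 1 and compound 2 stand at the limit of > 50000 nM in this assay, at which 2 of the 3 values shown sit. Compound 4 `CCCCCCCCCC(CCO)n1cnc2c(N)nc(Cl)nc21` comes from compound 3 by a single change amino in place of chloro on an aromatic carbon. Going by the values given here, the one measured step, a step that the two limits leave unreadable from compound 1 to compound 2, lies in the chain and has no readable size, so no step measures this change directly. Compound 2 carries the amino group too, on a different chain, and its > 50000 nM is a limit. On that ground a modest weakening in this assay is expected, a 1.5-fold higher number from compound 3 to compound 4 (0.17 log units; within the scatter). The estimate for compound 4 is 48000 nM, with an expected range from 20000 nM to 100000 nM.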

Compound 4, half-maximal inhibitory concentration: 14800 nM
Estimate against measurement, compound 4: 3.2-fold (0.51 log units) above; measured number outside the range, below it.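

In this assay amino in place of chloro on this aromatic carbon gives a 2.2-fold lower number from compound 3 to compound 4 (0.34 log units; beyond the scatter) and so supplies the first readable size for a change at this position. With the amino group kept, the longer chain gives an at least 3.3-fold lower number from compound 2 to compound 4 (0.52 log units; beyond the scatter) and also an at least 3.3-fold lower number from compound 1 to compound 4 (0.52 log units; beyond the scatter) in this short series. Both of these are bounds and not exact sizes, since compound 1 and compound 2 each stand at a limit: the limit of > 50000 nM in this assay, at which 2 of the 4 values shown sit.

The compounds shown leave open how a methylamino or hydroxyl group on this carbon would compare with amino. They also leave open whether a longer chain would lower the number further.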